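A few compounds are considered here, and "the series" means these few. Any claim that something is new, unique, unknown or untested is made for them only; others in the source may bear on it.

Measured compounds:
compound 1, `N#Cc1ccc(NC(=O)c2cc(Cc3ccccc3)ccc2O)cc1` — 1740 nM
compound 2, `O=C(Nc1cc(C(F)(F)F)cc(C(F)(F)F)c1)c1cc(Br)c(-c2ccccc2)cc1O` — 430 nM
compound 3, `N#Cc1ccc(NC(=O)c2cc(Br)c(-c3ccccc3)cc2O)cc1` — 700 nM

All three were read in a functional assay on HL-60 cells (Homo sapiens) for cytotoxicity, read by luminescence and CellTiter-Glo, with a stated time of 3 days; a higher number here means a weaker inhibitor, a lower number a stronger inhibitor. Compound 1 gives the highest number of the three; both compound 3 and compound 2 sit lower by amounts beyond the scatter, compound 2 furthest, so compound 1 is the weakest inhibitor of this set in this assay.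

Compound 4, `N#Cc1ccc(NC(=O)c2cc(-c3cccnc3)ccc2O)cc1`, is not yet measured. Compared with compound 1 the change is pyridin-3-yl in place of benzyl on an aromatic carbon. Going by the values given here, no measured pair isolates this change; compound 3 carries a phenyl directly on the core together with a bromine, so it does not settle the question. For compound 4 in this assay a small step toward a lower number, likely within the scatter, is expected: a 1.5-fold lower number from compound 1 to compound 4 (0.16 log units; within the scatter). Compound 4 is estimated at 1200 nM, range 400 nM to 3500 nM.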

Compound 4, half-maximal inhibitory concentration: 7960 nM
Compound 4: the middle estimate sits 6.6-fold (0.82 log units) below what was measured; measured number above the stated range.
By their numbers in this assay, from the lowest: compounds 2 and 3 (each within the scatter of the next); then compound 1; then compound 4.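

In this assay, the aromatic carbon para to the hydroxy group proves sensitive to what it carries: pyridin-3-yl in place of benzyl gives a 4.6-fold higher number from compound 1 to compound 4 (0.66 log units; beyond the scatter). Going by these compounds alone, this is the first single-place change, and it moves beyond the scatter toward a weaker inhibitor. Nothing available explains the step.

The step combines loss of the benzyl carbon link with entry of a ring nitrogen, and the compounds shown do not separate the two. On these data alone, how an amine or a carboxylic acid on this carbon would read remains open.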